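The compounds below may be only part of what the source reports. "The series", "measured", "known", "first", "only" and "open" are said of these compounds alone.

Three compounds share one core and differ only in the chain attached to its ether oxygen. Compound 1 `CCCCCCOc1ccc2c(Cl)ccnc2c1` carries a hexyl chain, while compound 2 `Clc1ccnc2cc(OCCCc3ccccc3)ccc12` and compound 3 `Clc1ccnc2cc(OCCc3ccccc3)ccc12` end their chains in a phenyl ring. In a functional assay on DLD-1 cells (Homo sapiens) for cytotoxicity, read by MTT assay, with a stated time of 48 h (a higher number here means a weaker inhibitor, a lower number a stronger inhibitor), compound 1 gives 2660 nM, compound 2 gives 2140 nM and compound 3 gives 3380 nM. Compound 1 thus holds the second highest of the three numbers, yet every pair sits within the scatter: a 1.2-fold lower number from compound 1 to compound 2 (0.09 log units; within the scatter), a 1.3-fold higher number from compound 1 to compound 3 (0.10 log units; within the scatter) and a 1.6-fold higher number from compound 2 to compound 3 (0.20 log units; within the scatter).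

Compound 4 `C=CCOc1ccc2c(Cl)ccnc2c1` differs from compound 1 by vinyl in place of pentyl on a saturated chain carbon bound to an oxygen on an aromatic ring. The three measured steps all trade the far end of a chain for a phenyl ring at roughly constant length, and none of them moved the number beyond the scatter. Cutting the chain down to allyl is a different kind of change, so those steps bear on it only loosely: they show that reshaping the chain end left the number where it was, but say nothing about a much shorter chain. The expectation is therefore a step from compound 1 to compound 4 of about a 1.2-fold higher number from compound 1 to compound 4 (0.08 log units; within the scatter) in this assay, with a wide band of uncertainty. Compound 4 is accordingly estimated at 3200 nM, within a range of 1400 nM to 8000 nM.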

Compound 4, half-maximal inhibitory concentration: 2890 nM
For compound 4 the middle estimate is 1.1-fold (0.04 log units) above the measured one; the measured number falls inside the stated range.
By their numbers in this assay, from the lowest: compounds 2, 1, 4 and 3 (each within the scatter of the next).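

Replacing hexyl with allyl, which is vinyl in place of pentyl on a saturated chain carbon bound to an oxygen on an aromatic ring, gives a 1.1-fold higher number from compound 1 to compound 4 (0.04 log units; within the scatter) in this assay. The earlier steps shown here only exchanged the far end of a chain for a phenyl ring, whereas this one removes much of the chain and leaves no ring on it, and the number still stays within the scatter, so at this position a far shorter chain is tolerated as well as the longer ones. Nothing measured here explains why the number holds so steady across these chains.

Shortening and the new double bond arrive together in this one step, so a saturated propyl chain would be needed to tell the two changes apart. All four chains are built only from carbon and hydrogen, which leaves open whether an amine or a carboxylic acid on the chain, or a chain longer than hexyl, would finally move the number beyond the scatter.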